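The source may hold more compounds than are shown below. What is called first, only, known or untested is meant among the compounds shown, and "the series" means these compounds.

Compound 1 `Cc1cc2cc(NS(=O)(=O)c3cc(C(=O)NO)ccc3Cl)ccc2n(C)c1=O` gives 59% in an assay on isolated protein for inhibition of protein deacetylase HDAC6 (Homo sapiens), read by fluorescence, with a stated time of 90 min, tested at 10 uM; a higher number here means a stronger effect of the compound at the concentration tested, a lower number a weaker effect.
Compound 2 `COc1ccc(C(=O)NO)cc1NCc1ccc(OCCCCC(=O)Nc2ccc3c(c2)cc(C)c(=O)n3C)cc1` gives 68% in this assay.

Going by the values given here, only these two compounds have a number so far. Compound 1 stands at the lower of the two numbers, with compound 2 the nearest, and the gap between them is within the scatter of repeated measurements, so the two cannot be told apart on strength. Among the compounds with values here, both share the same core, but the part that joins the core to the hydroxycarbamoyl-bearing ring is built differently in each, so no single-point step between them has been worked out.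

Compound 3 `COc1ccc(C(=O)NO)cc1S(=O)(=O)Nc1ccc2c(c1)cc(C)c(=O)n2C` has not yet been measured in this assay. It differs from compound 1 in one place: methoxy in place of chloro on an aromatic carbon. Everything else in the molecule is unchanged. Within the data shown here, no measured pair differs only in this way, so the expectation rests on compound 1 alone, with compound 2 showing that a methoxy-bearing compound can reach a similar number. In this assay a step of no size beyond the scatter is expected from this change. Compound 3 is therefore estimated at 60%, expected to fall between 42% and 78%. This estimate means an expected step of a number 1 percentage points higher from compound 1 to compound 3 (within the scatter).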

Compound 3, a percentage reported as inhibition, at one concentration (the size of the read-out at that concentration, not a potency): 64%
For compound 3 the middle estimate is 4 percentage points below the measured one; the range from low to high includes it.
By their numbers in this assay, from the lowest: compounds 1, 3 and 2 (each within the scatter of the next).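

Putting methoxy in place of chloro on the aromatic carbon that is ortho to a large group and para to a hydroxycarbamoyl group gives a number 5 percentage points higher from compound 1 to compound 3 (within the scatter) in this assay. Going by these compounds alone, this is the first direct one-place comparison at this position, and it shows that a two-atom group carrying a hydrogen-bond acceptor can stand where a single chlorine stood without a change that can be told from ordinary scatter, so these two groups cannot be separated here. No measurement at hand bears on why the two groups read alike.

From the compounds shown here alone, only chloro and methoxy are compared at this position, so it remains open whether a plain hydrogen, a fluorine, an amine or a longer ether such as ethoxy would also leave the number in this assay unmoved. The read-out also comes from a single concentration, so it shows only the size of the effect at that concentration, and compound 1 and compound 3 could still differ in a stronger or weaker effect at other concentrations, which these similar numbers cannot show.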